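Swapping pentyl for butylcarbonyl on compound 1

This account rests on a few compounds, and the source may have more. Where it says the series, first, only, none or still open, it means among the compounds named here.

Compound 1 `CCCCCOc1ccc2oc(/C=C/[S+](C)[O-])cc(=O)c2c1`: 1600 nM
Compound 2 `Cc1cccc2oc(/C=C/[S+](C)[O-])cc(=O)c12`: 1300 nM

In a functional assay on A549 cells (Homo sapiens) for cytotoxicity, with a stated time of 48 h (a higher number here means a weaker inhibitor, a lower number a stronger inhibitor), compound 1 gives 1600 nM, the higher of the two numbers but within the usual scatter of compound 2 at 1300 nM. Compound 3 `CCCCC(=O)Oc1ccc2oc(/C=C/[S+](C)[O-])cc(=O)c2c1` keeps the core of compound 1 and carries butylcarbonyl in place of pentyl on an oxygen on an aromatic ring. Going by the values given here, no measured pair shows what this swap does in this assay, so no change beyond the scatter is expected, and the expected step of a 1.1-fold lower number from compound 1 to compound 3 (0.06 log units; within the scatter) is small. For compound 3 the estimated value is 1400 nM, with an expected range of 500 nM to 4000 nM.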

Compound 3, half-maximal inhibitory concentration: 2400 nM
The estimate for compound 3 lay 1.7-fold (0.23 log units) below the measured number; measured number inside the range.
By their numbers in this assay, from the lowest: compounds 2, 1 and 3 (each within the scatter of the next).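

In this assay, butylcarbonyl in place of pentyl on an oxygen on an aromatic ring gives a 1.5-fold higher number from compound 1 to compound 3 (0.18 log units; within the scatter) and so stays within the scatter. At this position, then, pentyloxy and (butylcarbonyl)oxy cannot be told apart by this read-out, even though the swap adds a carbonyl and a hydrogen-bond acceptor. Nothing measured here bears on what lies behind this small step. Still open, from the compounds shown here alone, is whether a group of another kind at this place, such as an amine, a carboxylic acid or a much longer chain, would move the number beyond the scatter.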